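The source may report more compounds than this note shows. Statements on the series, on what has been measured and on what is new or still open speak of the compounds shown alone.

Among the compounds with values here, compound 3 `O=C(C[C@@H]1CCCCN1S(=O)(=O)c1cccc(C(F)(F)F)c1)N[C@@H]1CCCc2cc(CNCC3CC3)ccc21` is one of three compounds measured in a functional assay for inhibition of B1 bradykinin receptor (Homo sapiens), read by calcium flux; a lower number here means a stronger inhibitor, a higher number a weaker inhibitor. In this assay compound 3 gives 31 nM, the highest of the three numbers, yet this number sits within the usual scatter of both of its neighbours: compound 1 `Cc1ccc(S(=O)(=O)N2CCCC[C@H]2CC(=O)N[C@@H]2CCCc3cc(CNC(C)(C)C)ccc32)cc1Cl` gives 22 nM in this assay, and compound 2 `Cc1ccc(S(=O)(=O)N2CCCC[C@H]2CC(=O)N[C@@H]2CCCc3cc(CNC(C)(C)C)ccc32)cc1C(F)(F)F` gives 16 nM. Within the data shown here, the one step between measured compounds that differ in a single place, a 1.4-fold lower number from compound 1 to compound 2 (0.14 log units; within the scatter), concerns the substituent on the aromatic carbon of the sulfonyl-bearing ring and stays within the scatter.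

Compound 4 `O=C(C[C@@H]1CCCCN1S(=O)(=O)c1cccc(C(F)(F)F)c1)N[C@@H]1CCCc2cc(CN3CCC3)ccc21` differs from compound 3 elsewhere: azetidin-1-yl in place of (cyclopropylmethyl)amino on a saturated chain carbon bound to an aromatic carbon. Among the measured compounds shown here, no measured pair shows this change, and the step from compound 1 to compound 2 lies in another part of the molecule, so it gives no direct guide. With nothing in the measured data pointing to a shift beyond the scatter, compound 4 is expected to come out close to compound 3, the estimated step being a 1.3-fold higher number from compound 3 to compound 4 (0.11 log units; within the scatter). Compound 4 is therefore estimated at 40 nM in this assay, with a range from 15 nM to 110 nM.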

Compound 4, half-maximal inhibitory concentration: 4300 nM
Compound 4: the middle estimate sits 110-fold (2.03 log units) below what was measured, outside the stated range (above it).
By their numbers in this assay, from the lowest: compounds 2, 1 and 3 (each within the scatter of the next); then compound 4.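

In this assay, within the data shown here, a 140-fold higher number from compound 3 to compound 4 (2.14 log units; beyond the scatter) shows that this place, on a saturated chain carbon bound to an aromatic carbon, can move the number far beyond the scatter, whereas the only earlier step, a 1.4-fold lower number from compound 1 to compound 2 (0.14 log units; within the scatter), lay elsewhere in the molecule and stayed within it. The change replaces (cyclopropylmethyl)amino, with 1 hydrogen-bond donor, by azetidin-1-yl, with 0 hydrogen-bond donors, and it also alters the ring, so this single pair cannot separate the two differences. Nothing available gives a measured reason for the large step.

On these data alone, it remains open whether a cyclobutylamino group, which keeps the nitrogen-bound hydrogen, or a dimethylamino group, which has no ring, would fall nearer compound 3 or compound 4. As far as these compounds go, it is also open whether the same change would have as large an effect on the core of compound 2.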